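A few compounds are considered here, and "the series" means these few. Any claim that something is new, unique, unknown or untested is made for them only; others in the source may bear on it.

Values in a functional assay on K562 cells (Homo sapiens) for antiproliferative activity, read by resazurin assay, with a stated time of 72 h; a lower number here means a stronger inhibitor of growth, a higher number a weaker inhibitor of growth:
- compound 1, `CCCCCCCCCCCC/C=C\N(NC(=O)COC)C(=O)CCCCCCCCC`: > 110000 nM (a limit)
- compound 2, `CCCCCCCCCCCC/C=C\N(NC(=O)COC)C(=O)OC(C)(C)C`: 28300 nM
- compound 3, `CCCCCCCCCCNNC(=O)COC`: 167000 nM

Compound 1 has no exact number and stands at a limit: the limit of > 110000 nM in this assay, at which 1 of the 3 values shown sits.

The next compound, compound 4, `CCCCCCCCCCCC/C=C\N(NC(=O)CCl)C(=O)CCCCCCCCC`, keeps the core of compound 1 and changes one group: chloro in place of methoxy on a saturated chain carbon bound to a carbonyl carbon. This places chloro in place of methoxy on a saturated chain carbon bound to a carbonyl carbon. For the measured compounds named here, all three measured compounds carry methoxy, so no measured step covers this exchange.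

Going by the values given here, the one step available is an at least 3.8-fold lower number from compound 1 to compound 2 (0.58 log units; beyond the scatter), with tert-butoxy in place of nonyl on a carbonyl carbon. It lies at another place in the structure and serves only as a rough guide to how far a single change can move a value in this series. With so little support, and with a limit as the starting point, the forecast is loose. A lower number in this assay is expected, by a step of about the same size as that one, and a result that again stays at a limit would not be surprising.

The expected change is an at least 2.7-fold lower number from compound 1 to compound 4 (0.43 log units; beyond the scatter). For compound 4 the estimate is 40000 nM, with an expected range of 8000 nM to 110000 nM.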

Compound 4, concentration for 50% growth inhibition: 18400 nM
The estimate for compound 4 lay 2.2-fold (0.34 log units) above the measured number, within the range that was stated.
By their numbers in this assay, from the lowest: compounds 4 and 2 (each within the scatter of the next); then compound 3.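

In this assay, the exchange at this position gives an at least 5.9-fold lower number from compound 1 to compound 4 (0.77 log units; beyond the scatter). For the compounds shown here, this is the first readable change on a saturated chain carbon bound to a carbonyl carbon, and it shows that this place affects the read-out even with the nonyl carbonyl group of compound 1 kept, whereas the only earlier step lay at that other carbonyl group. The figure is only a bound on the size of the step, because compound 1 stands at a limit and not at a number: the limit of > 110000 nM in this assay, at which 1 of the 4 values shown sits.

On these data alone, only methoxy and chloro appear at this position, so it stays open whether the gain follows from chloro itself or from the loss of methoxy, and whether bromo, hydroxy or a dimethylamino group would give a similar value. As far as these compounds go, it is also open whether chloro and tert-butoxy, each linked to a lower number when exchanged on compound 1, would add up in one compound, and no property can yet be assigned to either exchange from these values.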